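A few compounds are considered here, and "the series" means these few. Any claim that something is new, unique, unknown or untested is made for them only; others in the source may bear on it.

Compound 1 `Fc1ccc(C2(c3ccc(F)cc3)CNC(c3cccc(Br)c3)=N2)cc1`: 4.8 nM
Compound 2 `Cc1cccc(C2=NC(c3ccc(F)cc3)(c3ccc(F)cc3)CN2)c1`: 30 nM
Compound 3 `Fc1ccc(C2(c3ccc(F)cc3)CNC(c3cccnc3)=N2)cc1`: 7.2 nM

In an assay on LM cells for displacement of a labelled ligand from Neuropeptide Y receptor type 5 (Homo sapiens) (on this read-out higher numbers stand for weaker inhibition and lower numbers for stronger inhibition), compound 3 gives the second highest of these three numbers. Its nearest neighbour is compound 1, since a 1.5-fold higher number from compound 1 to compound 3 (0.18 log units; within the scatter) stays within the scatter; compound 2 is furthest, since a 4.2-fold lower number from compound 2 to compound 3 (0.62 log units; beyond the scatter) lies beyond it. Compound 4 `N#Cc1cc(C2=NC(c3ccc(F)cc3)(c3ccc(F)cc3)CN2)ccn1` differs from compound 3 by 2-cyanopyridin-4-yl in place of pyridin-3-yl on a carbon with a double bond to nitrogen. Within the data shown here, no measured step swaps one pyridyl group for another, so nothing bears directly on this change; the two steps that alter the group on the same carbon show that such swaps move this assay only modestly. A modest shift, more likely toward a higher number, is therefore expected, estimated as a 2.1-fold higher number from compound 3 to compound 4 (0.32 log units; beyond the scatter). Compound 4 is expected to give 15 nM, with a range from 4 nM to 60 nM.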

Compound 4, half-maximal inhibitory concentration: 4.8 nM
The estimate for compound 4 lay 3.1-fold (0.49 log units) above the measured number; the range from low to high includes it.
By their numbers in this assay, from the lowest: compounds 1, 4 and 3 (each within the scatter of the next); then compound 2.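

In this assay, this position tolerates 2-cyanopyridin-4-yl, with its triple bond and extra hydrogen-bond acceptor: the number stays level with pyridin-3-yl (a 1.5-fold lower number from compound 3 to compound 4 (0.18 log units; within the scatter)) and with 3-bromophenyl (no change at the digits printed from compound 1 to compound 4 (within the scatter)). Against 3-methylphenyl the new group does differ (a 6.3-fold lower number from compound 2 to compound 4 (0.80 log units; beyond the scatter)), so compound 2 alone stands apart in this set. No available evidence explains these results.

Open, going by these compounds, is how a group carrying an amine or a carboxylic acid would behave on this carbon. Also open, on these data alone, is whether a simple alkyl chain could replace the aromatic ring here.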